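Methyl in Place of Hydrogen: Expectation for Compound 3

The compounds below may be only part of what the source reports. "The series", "measured", "known", "first", "only" and "open" are said of these compounds alone.

Compound 1, `COC(=O)[C@@]1(C)CCC=C2[C@@H]1CC[C@@H](C)[C@]2(C)Cc1c[nH]c2ccc(F)cc12`: 7300 nM
Compound 2, `COC(=O)[C@@]1(C)CCC=C2[C@@H]1CC[C@@H](C)[C@]2(C)Cc1c[nH]c2ccc(OC)cc12`: 1300 nM

Both numbers come from a functional assay on SW1573 cells (Homo sapiens) for inhibition, read by sulforhodamine B assay, with a stated time of 48 h; on this read-out lower numbers stand for stronger inhibition of growth and higher numbers for weaker inhibition of growth. Compound 2 gives the lower of the two; the change from compound 1 is a 5.6-fold lower number from compound 1 to compound 2 (0.75 log units; beyond the scatter), so compound 2 stands clearly apart from compound 1 in this assay.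

Compound 3, `COC(=O)[C@@]1(C)CCC=C2[C@@H]1CC[C@@H](C)[C@]2(C)Cc1c(C)[nH]c2ccc(OC)cc12`, differs from compound 2 by methyl in place of hydrogen on an aromatic carbon. Among the measured compounds shown here, no measured step bears on this change: the only step known, from compound 1 to compound 2, concerns a methoxy in place of a fluoro on a different aromatic carbon and says nothing about a methyl at this place. With nothing in the numbers to point either way, a step within the scatter, or none, is expected. Compound 3 is therefore estimated at 1300 nM in this assay, with a range from 400 nM to 4500 nM, which means an expected step of no change at the digits printed from compound 2 to compound 3 (within the scatter).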

Compound 3, concentration for 50% growth inhibition: 15000 nM
Compound 3: middle estimate off by 12-fold (1.06 log units), on the low side; measured number above the stated range.
By their numbers in this assay, from the lowest: compound 2; then compound 1; then compound 3.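

Methyl in place of hydrogen on an aromatic carbon of the five-membered aromatic ring, next to the ring nitrogen and next to the ring atom that bears a large group, is far from a silent change in this assay: it gives a 12-fold higher number from compound 2 to compound 3 (1.06 log units; beyond the scatter), a large weakening of growth inhibition. Among the compounds shown here, the earlier pair varied only a different aromatic carbon, so this is the first sign that this place is sensitive to substitution, and here a single added carbon outweighs the gain seen on going from fluoro to methoxy. Nothing available gives a reason for this loss.

Going by these compounds, whether a longer chain such as ethyl, or an aminomethyl group, at this place would weaken growth inhibition as strongly remains open. Also open, on these data alone, is whether the same methyl would have a similar effect alongside the fluoro of compound 1.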